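The source may hold more compounds than are shown below. What is called first, only, known or untested is meant among the compounds shown, and "the series" means these compounds.

Three compounds share one core, and each has been tested in a functional assay on RAW264.7 cells (Mus musculus) for inhibition, with a stated time of 4 days; a lower number here means a stronger inhibitor, a higher number a weaker inhibitor. Compound 1 `COc1ccc(/C=C/C(=O)c2cccc(N=[N+]=[N-])c2)cc1O` gives 1960 nM. Compound 2 `COc1cc(/C=C/C(=O)c2cccc(-n3cc(-c4ccccc4)nn3)c2)ccc1O` gives 16800 nM. Compound 3 `COc1ccc(/C=C/C(=O)c2cccc(-n3cc(-c4ccccc4)nn3)c2)cc1O` gives 1510 nM, the lowest of the three numbers; the value of compound 1 sits within the scatter of it, and only compound 2 is separated from it beyond the scatter. Within the data shown here, the one step that can be followed in a single change is an 11-fold lower number from compound 2 to compound 3 (1.05 log units; beyond the scatter), which concerns the aromatic ring on the double-bonded chain, not the ring that changes next.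

Compound 4 `COc1ccc(/C=C/C(=O)c2cccc(-n3cc(-c4ccc(Br)cc4)nn3)c2)cc1O` differs from compound 3 in one place: bromo in place of hydrogen on an aromatic carbon. Among the measured compounds shown here, no measured pair shows what a bromo on this ring does, so there is no step that bears on the change, and the one measured step touches another part of the molecule. With nothing to support a shift, the number for compound 4 in this assay is expected to stay close to that of compound 3, with a step of a 1.0-fold lower number from compound 3 to compound 4 (0.00 log units; within the scatter) expected to fall within the usual scatter. The estimate for compound 4 is therefore 1500 nM, within a range from 600 nM to 4000 nM.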

Compound 4, half-maximal inhibitory concentration: 6570 nM
Compound 4: middle estimate off by 4.4-fold (0.64 log units), on the low side; measured number outside the range, above it.
By their numbers in this assay, from the lowest: compounds 3 and 1 (each within the scatter of the next); then compound 4; then compound 2.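

In this assay, the far phenyl ring of the core is not a neutral place to add a group: changing phenyl to 4-bromophenyl, with one bromine atom para to a large group, gives a 4.4-fold higher number from compound 3 to compound 4 (0.64 log units; beyond the scatter). The number therefore moves in the weaker direction, beyond the scatter, after a change of only a single heavy atom. Among these compounds, the earlier compounds could not show this, since the only step that could be followed among them lay on the aromatic ring of the double-bonded chain, so this is the first sign that the far phenyl ring also responds to change. Nothing available here explains why the bromo raises the number.

A single substituent at a single place cannot show whether this rise belongs to bromo alone or would come with any group there, and fluoro, chloro, methoxy or an amine at the same carbon would begin to separate those two readings. From the compounds shown here alone, it also remains open whether bromo on the ring would give a similar step with the 4-hydroxy-3-methoxyphenyl group of compound 2 in place of the 3-hydroxy-4-methoxyphenyl group.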